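The compounds below may be only part of what the source reports. "The series", "measured", "known", "first", "only" and "open" are said of these compounds alone.

Measured compounds:
Compound 1, `O=C(Nc1ccc(C(F)(F)F)cc1)c1cc(Cl)c(-c2ccccc2)cc1O`: 770 nM
Compound 2, `O=C(Nc1ccc(C(F)(F)F)cc1)c1cc(Br)ccc1O`: 610 nM
Compound 3, `O=C(Nc1ccc(C(F)(F)F)c(Cl)c1)c1cc(Cl)ccc1O`: 450 nM

Of the compounds shown here, three have so far been tested in a functional assay on KG-1 cells (Homo sapiens) for cytotoxicity, read by luminescence and CellTiter-Glo, with a stated time of 3 days; on this read-out lower numbers stand for stronger inhibition and higher numbers for weaker inhibition. Compound 1 `O=C(Nc1ccc(C(F)(F)F)cc1)c1cc(Cl)c(-c2ccccc2)cc1O` gives 770 nM in this assay, compound 2 `O=C(Nc1ccc(C(F)(F)F)cc1)c1cc(Br)ccc1O` gives 610 nM, and compound 3 `O=C(Nc1ccc(C(F)(F)F)c(Cl)c1)c1cc(Cl)ccc1O` gives 450 nM. Compound 3 carries the lowest of the three numbers, but the gap to compound 2 and the gap to compound 1 both lie within the scatter of repeated measurements, so no order among the three can be read from these values.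

Compound 4 `O=C(Nc1ccc(C(F)(F)F)cc1)c1cc(Cl)ccc1O` has not yet been measured in this assay. It differs from compound 3 in one place: hydrogen in place of chloro on an aromatic carbon. Among the compounds with values here, no pair of measured compounds differs by this same change, so there is no measured step to lean on. With only a single chlorine leaving, the expectation is a small step, if any, with a slight lean toward a higher number for compound 4, and the estimated step of a 1.3-fold higher number from compound 3 to compound 4 (0.12 log units; within the scatter) is expected to stay within the scatter. Compound 4 is therefore expected to give about 600 nM in this assay, with a plausible range from 300 nM to 1200 nM.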

Compound 4, half-maximal inhibitory concentration: 740 nM
The estimate for compound 4 lay 1.2-fold (0.09 log units) below the measured number, within the range that was stated.
By their numbers in this assay, from the lowest: compounds 3, 2, 4 and 1 (each within the scatter of the next).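

In this assay, hydrogen in place of the chloro ortho to a trifluoromethyl group gives a 1.6-fold higher number from compound 3 to compound 4 (0.22 log units; within the scatter) and so shows that, as far as this read-out can tell, this position accepts either atom. The other two single changes, both on the ring that carries the hydroxyl group, read the same way: chloro in place of bromo gives a 1.2-fold higher number from compound 2 to compound 4 (0.08 log units; within the scatter) and hydrogen in place of phenyl gives a 1.0-fold lower number from compound 1 to compound 4 (0.02 log units; within the scatter) and thus even a whole phenyl ring coming or going leaves the number within the scatter. No independent measurement is available to explain why these numbers stay so close.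

The compounds shown leave open whether any group at the position ortho to the trifluoromethyl group would move the number beyond the scatter, for instance a methoxy group, an amine or a nitrile in place of the chloro. They also leave open what happens when the hydroxyl group itself is replaced, for example by a methoxy group, since it stays the same throughout all four compounds.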